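Ether chain series: phenyl in place of allyl

The source may hold more compounds than are shown below. What is called first, only, known or untested is meant among the compounds shown, and "the series" means these compounds.

Measured in a functional assay on PC-3 cells (Homo sapiens) for inhibition, read by colorimetric assay and MTT assay, with a stated time of 72 h; on this read-out higher numbers stand for weaker inhibition and lower numbers for stronger inhibition:
compound 1 `COc1ccccc1-c1cnc(OC)n1C`: > 100000 nM
compound 2 `C=CCCOc1ncc(-c2ccccc2OC)n1C`: 25000 nM
compound 3 `C=CCCCCOc1ncc(-c2ccccc2OC)n1C`: 24000 nM

The entry for compound 1 is a limit of the assay and not a number. For the measured compounds named here, compound 3 stands at 24000 nM, level with the only other true number in the set. Compound 4 `COc1ccccc1-c1cnc(OCCCc2ccccc2)n1C` is the next to be read, with phenyl in place of allyl on a saturated chain carbon, three bonds along the chain from an oxygen on an aromatic ring. Two measured steps show the gain from adding an alkenyl chain to the ether: an at least 4.0-fold lower number from compound 1 to compound 2 (0.60 log units; beyond the scatter) and an at least 4.1-fold lower number from compound 1 to compound 3 (0.61 log units; beyond the scatter). Both start from the limit, so their true size is open. The step closest to this change is a 1.0-fold lower number from compound 2 to compound 3 (0.02 log units; within the scatter), a change at the chain end that stayed within the scatter. On that basis, only a small step or none is expected in this assay, with a slight lean towards a lower number. Going by the values given here, no measured compound carries phenyl at the chain end, so the range stays wide. The expected step is a 1.6-fold lower number from compound 3 to compound 4 (0.20 log units; within the scatter). Compound 4 is estimated at 15000 nM, with an expected range of 5000 nM to 50000 nM.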

Compound 4, half-maximal inhibitory concentration: 27000 nM
For compound 4 the middle estimate is 1.8-fold (0.26 log units) below the measured one; the measured number falls inside the stated range.
By their numbers in this assay, from the lowest: compounds 3, 2 and 4 (each within the scatter of the next). At a limit, above all of these: compound 1.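

In this assay, phenyl in place of allyl, on a saturated chain carbon three bonds along the chain from an oxygen on an aromatic ring, gives a 1.1-fold higher number from compound 3 to compound 4 (0.05 log units; within the scatter), and the wider change gives a 1.1-fold higher number from compound 2 to compound 4 (0.03 log units; within the scatter), so an aromatic ring at the chain end reads the same as the alkenyl ends. The gain over the short ether also holds with this new end, at an at least 3.7-fold lower number from compound 1 to compound 4 (0.56 log units; beyond the scatter). Compound 1 stands at a limit and not a number, so that step gives a bound only: the limit of > 100000 nM in this assay, at which 1 of the 4 values shown sits.

The chain ends shown, alkenyl and phenyl, do not separate from one another, so what this position responds to remains open. Whether an amine or a carboxylic acid at the chain end would shift the number is not settled by the compounds shown.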